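The compounds below may be only part of what the source reports. "The series", "measured", "known", "first", "only" and "open" are said of these compounds alone.

The series shares the core seen in compound 3 `CCOc1ccc(C(=O)Nc2cc3nc(C4CCCCC4)[nH]c3cc2N(CC)CC)cc1`, an amide whose carbonyl carbon carries a varied aryl group. In an ADME assay on Vero cells (Chlorocebus sabaeus) for cytotoxicity, read by resazurin assay, with a stated time of 3 days (on this read-out lower numbers stand for stronger inhibition and higher numbers for weaker inhibition), compound 3 gives only a limit, > 100 ug/mL. Compound 2 `C=Cc1cccc(C(=O)Nc2cc3nc(C4CCCCC4)[nH]c3cc2N(CC)CC)c1` likewise gives only a limit in this assay, > 100 ug/mL. Compound 1 `CCCc1ccc(C(=O)Nc2cc3nc(C4CCCCC4)[nH]c3cc2N(CC)CC)cc1` has no result in this assay, "not determined" (no result reported). The step that the two limits leave unreadable from compound 2 to compound 3 cannot be read, since both ends sit at the limit of > 100 ug/mL in this assay, at which 2 of the 3 values shown sit, so the exchange of aryl group leaves no measurable footprint here. Compound 4 `CCN(CC)c1cc2[nH]c(C3CCCCC3)nc2cc1NC(=O)c1cccc(Br)c1` differs from compound 3 by 3-bromophenyl in place of 4-ethoxyphenyl on a carbonyl carbon. For the measured compounds named here, the only measured step on an aryl exchange, from compound 2 to compound 3, is unreadable, so no direction can be drawn for the present change; what the numbers show is that two of the three entries sit at the limit. Compound 4 is therefore expected to stay at the same limit, with the step of a number no higher from compound 3 to compound 4 (the limit leaves the size open) expected to be none beyond the scatter. In this assay compound 4 is expected at 100 ug/mL, ranging from 50 ug/mL to 200 ug/mL.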

Compound 4, half-maximal inhibitory concentration: > 100 ug/mL
Compound 4 gave a limit, no number; the forecaster's own chance of this, stated with the estimate: 75%; the middle value lies on the limit itself.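

No step to compound 4 can be read from compound 2 or compound 3 in this assay, because all three give only a limit: the limit of > 100 ug/mL in this assay, at which 3 of the 4 values shown sit.

As far as these compounds go, whether any aryl group on the shared core gives a number rather than a limit in this assay stays open.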